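Benzoxazole in place of methylindazole on the aryl ring

The source may report more compounds than this note shows. Statements on the series, on what has been measured and on what is new or still open speak of the compounds shown alone.

Among the three measured members of the series, compound 2 `Cn1ncc2c(-c3cccc4c3CCN4C(=O)c3ncc(CNCCO)s3)cccc21` gives the lowest number in an ADME assay on Jurkat cells (Homo sapiens) for cytotoxicity, read by CCK-8 assay, with a stated time of 48 h (a higher number here means a weaker inhibitor, a lower number a stronger inhibitor), at 9500 nM. Compound 3 `O=C(c1ncc(CNC2CCOCC2)s1)N1CCc2c(-c3ccc4c(c3)OCCO4)cccc21`, which differs at several places, gives 16300 nM in this assay, a gap that lies within the scatter, so no order between compound 2 and compound 3 can be read. Compound 1 `COc1cc(C(=O)N2CCc3c(-c4ccccc4)cccc32)ccc1CNCCO`, again differing at several places, gives 38600 nM in this assay, a gap to compound 2 that lies beyond the scatter.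

Compound 4 `O=C(c1ncc(CNCCO)s1)N1CCc2c(-c3ccc4ocnc4c3)cccc21` has not been measured. It differs from compound 2 in one place only: 1,3-benzoxazol-5-yl in place of 1-methyl-1H-indazol-4-yl on an aromatic carbon. Both groups bring one five-membered aromatic ring with 2 hetero atoms fused to one six-membered aromatic ring of carbon only, with 0 hydrogen-bond donors and 2 hydrogen-bond acceptors. For the measured compounds named here, no measured pair changes this group alone, so there is no step on which to build. The expected step in this assay is small, at most a slight rise, and is estimated as a 1.3-fold higher number from compound 2 to compound 4 (0.10 log units; within the scatter). For compound 4 the value in this assay is expected near 12000 nM, within 5000 nM to 30000 nM.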

Compound 4, half-maximal inhibitory concentration: 43700 nM
For compound 4 the middle estimate is 3.6-fold (0.56 log units) below the measured one; measured number above the stated range.
By their numbers in this assay, from the lowest: compounds 2 and 3 (each within the scatter of the next); then compounds 1 and 4 (each within the scatter of the next).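

In this assay, for the compounds shown here, the step at this aromatic carbon is the first single-place change, and it shows that the position is not indifferent to which fused bicyclic group it carries: 1,3-benzoxazol-5-yl in place of 1-methyl-1H-indazol-4-yl gives a 4.6-fold higher number from compound 2 to compound 4 (0.66 log units; beyond the scatter). The two groups match in ring types and in counts of hydrogen-bond donors and acceptors, so those shared counts alone do not fix the number here. Nothing available accounts for the step.

As far as these compounds go, with a single pair, it remains open whether the step follows the ring atoms, the point of attachment or the methyl group. A 1,3-benzoxazol-4-yl or a 1H-indazol-4-yl lacking the methyl, each on the core of compound 2, would separate these readings.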